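Two Measured Compounds and a Third Awaiting a Number

A few compounds are considered here, and "the series" means these few. Any claim that something is new, unique, unknown or untested is made for them only; others in the source may bear on it.

compound 1 `Cc1ccc(C(c2ccc(C)cc2)N2CCN(C(=O)COc3ccc4ccccc4c3)CC2)cc1`: 4.75%
compound 2 `COc1ccc(C(c2ccc(OC)cc2)N2CCN(C(=O)COc3ccccc3C)CC2)cc1`: 2.45%

In a functional assay on PC-12 cells (Rattus norvegicus) for cytotoxicity, read by MTT assay, with a stated time of 24 h, tested at 0.1 uM (on this read-out higher numbers stand for a stronger effect at the one concentration tested and lower numbers for a weaker effect), compound 1 gives 4.75% and compound 2 gives 2.45%. These two numbers lie within the usual scatter of each other, so compound 1 does not stand apart from compound 2. Compound 3 `COc1ccc(OCC(=O)N2CCN(C(c3ccc(C)cc3)c3ccc(C)cc3)CC2)cc1` has not yet been measured. It differs from compound 1 by 4-methoxyphenyl in place of naphthalen-2-yl on an oxygen on a saturated carbon. For the measured compounds named here, no measured pair differs in a single place, so nothing shows how such a change plays out in this assay. With both measured numbers low, the step of a number 0.8 percentage points lower from compound 1 to compound 3 (within the scatter) is expected to stay within the scatter. Compound 3 is estimated at 4%, between 0% and 12%.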

Compound 3, a percentage reported as activity, at one concentration (the size of the read-out at that concentration, not a potency): 21.7%
Beside the measured number, compound 3's estimate is 17.7 percentage points below it; the whole stated range lies below it.
By their numbers in this assay, from the lowest: compounds 2 and 1 (each within the scatter of the next); then compound 3.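

In this assay, the group on an oxygen on a saturated carbon turns out to matter: 4-methoxyphenyl in place of naphthalen-2-yl brings a number 17 percentage points higher from compound 1 to compound 3 (beyond the scatter). For the compounds shown here, this is the first single-place step in the set, and it shows that the smaller group with one aromatic ring and one hydrogen-bond acceptor does not leave the read-out low. Nothing available explains this rise.

Going by these compounds, whether the step follows the methoxy group or the loss of the second aromatic ring stays open, and a plain phenyl on that oxygen would separate the two. Also open, on these data alone, is whether the same change carries over to the core of compound 2.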